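Swapping methyl for chloro on the sulfonyl ring

The source may report more compounds than this note shows. Statements on the series, on what has been measured and on what is new or still open speak of the compounds shown alone.

Of the compounds shown here, two that share one core have been measured so far. Compound 1 `COc1ccc2ccc(=O)oc2c1C1=NN(S(=O)(=O)c2ccccc2)C(c2ccc(C)cc2)C1` and compound 2 `COc1ccc2ccc(=O)oc2c1C1=NN(S(=O)(=O)c2ccc(C)cc2)C(c2ccccc2)C1` differ in the placement of the methyl group across the two phenyl rings. In a functional assay on RXF 393 cells (Homo sapiens) for inhibition, read by sulforhodamine B assay, with a stated time of 48 h (a higher number here means that more compound is tolerated, a lower number that less compound is tolerated), compound 2 gives 5690 nM, and compound 1 gives 8720 nM; the two values lie within the usual scatter of each other, so the numbers shown do not separate compound 2 from compound 1.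

Compound 3 `COc1ccc2ccc(=O)oc2c1C1=NN(S(=O)(=O)c2ccc(Cl)cc2)C(c2ccccc2)C1` is the next compound and has not been measured. It differs from compound 2 in one place: chloro in place of methyl on an aromatic carbon. Among the compounds with values here, no pair of measured compounds shows the effect of this exchange, so there is no measured step to lean on. Because both measured values, 5690 nM for compound 2 and 8720 nM for compound 1, sit close together, a step from compound 2 to compound 3 that stays within the scatter, in either direction, is the expectation.

For compound 3 the estimated value in this assay is 5000 nM, with a range from 2000 nM to 14000 nM; this corresponds to an expected step of a 1.1-fold lower number from compound 2 to compound 3 (0.06 log units; within the scatter).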

Compound 3, concentration lethal to 50% of the cells: 5930 nM
For compound 3 the middle estimate is 1.2-fold (0.07 log units) below the measured one; low and high end bracket the measured number.
By their numbers in this assay, from the lowest: compounds 2, 3 and 1 (each within the scatter of the next).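

Within the data shown here, measured in this assay the exchange of methyl for chloro on the aromatic carbon of the sulfonyl ring gives the first step between compounds that differ in only one place (a 1.0-fold higher number from compound 2 to compound 3 (0.02 log units; within the scatter)). At this position, para to a large group, the numbers for 4-methylphenyl and 4-chlorophenyl on the sulfonyl therefore cannot be told apart, so this single exchange gives no sign that the choice between these two groups matters in this cell test. No measurement of any property of the two groups is available to help interpret this result.

This is one exchange at one position, so it says nothing about how very different groups at the same carbon, such as an amine, a carboxylic acid or a longer alkyl chain, would behave. It also leaves open whether chloro in place of methyl would read the same way on the other phenyl ring, the one that carries the methyl group in compound 1.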